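Expected drop in the number for compound 4

The source may report more compounds than this note shows. Statements on the series, on what has been measured and on what is new or still open speak of the compounds shown alone.

In a functional assay on K562 cells (Homo sapiens) for cytotoxicity, read by trypan blue exclusion, with a stated time of 96 h (a higher number here means a weaker inhibitor, a lower number a stronger inhibitor), compound 3 `COC(=O)C(Nc1cc(NS(=O)(=O)/C=C/c2c(OC)cc(OC)cc2OC)ccc1OC)c1ccccc1` gives 2500 nM, the highest number of the three measured. Compound 1 `COc1cc(OC)c(/C=C/S(=O)(=O)Nc2ccc(OC)c(F)c2)c(OC)c1` gives 75 nM, and compound 2 `COc1cc(OC)c(/C=C/S(=O)(=O)Nc2ccc(OC)c(OP(=O)(O)O)c2)c(OC)c1` gives 7.5 nM. Compound 4 `COc1cc(OC)c(/C=C/S(=O)(=O)Nc2ccc(OC)c(NC(C)C(=O)O)c2)c(OC)c1` has not yet been measured. The change from compound 3 sits on a nitrogen on an aromatic ring: 1-carboxyethyl in place of methoxycarbonyl)(benzyl on a nitrogen on an aromatic ring. The six-membered aromatic ring of carbon only leaves with the methoxycarbonyl)(benzyl group.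

Two large measured steps bear on this, both ending at the group that carries that ring: a 33-fold higher number from compound 1 to compound 3 (1.52 log units; beyond the scatter) and a 330-fold higher number from compound 2 to compound 3 (2.52 log units; beyond the scatter). A further step, a 10-fold lower number from compound 1 to compound 2 (1.00 log units; beyond the scatter), shows that a group with no ring can read lower still. Compound 4 has no such ring, and like compound 1 at 75 nM it is expected to read far below compound 3. Among the measured compounds shown here, no measured compound carries the 1-carboxyethyl group, which leaves the size uncertain. The expected change is a 21-fold lower number from compound 3 to compound 4 (1.32 log units; beyond the scatter). The estimate for compound 4 is 120 nM, with an expected range of 25 nM to 700 nM.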

Compound 4, half-maximal inhibitory concentration: 8 nM
Compound 4: the middle estimate sits 15-fold (1.18 log units) above what was measured; the measured number lies below the stated range.
By their numbers in this assay, from the lowest: compounds 2 and 4 (each within the scatter of the next); then compound 1; then compound 3.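

In this assay, the step to 1-carboxyethyl on a nitrogen on an aromatic ring is a 310-fold lower number from compound 3 to compound 4 (2.49 log units; beyond the scatter), so a nitrogen at this position is compatible with a low number and the high number of compound 3 goes with the methoxycarbonyl)(benzyl group it carries. The (1-carboxyethyl)amino group also improves on fluoro, with a 9.4-fold lower number from compound 1 to compound 4 (0.97 log units; beyond the scatter), while the step against the phosphorus-bearing group is a 1.1-fold higher number from compound 2 to compound 4 (0.03 log units; within the scatter), so these two ringless groups cannot be told apart here. Nothing available gives a reason for these differences.

The step from compound 3 to compound 4 removes the six-membered aromatic ring and exchanges the methyl ester for a carboxylic acid at once, and the compounds shown do not separate these two changes. Nor do they show how a plain amine or a longer chain ending in a carboxylic acid would read at this position.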